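Lengthening the chain of compound 2

The source may report more compounds than this note shows. Statements on the series, on what has been measured and on what is new or still open speak of the compounds shown alone.

Measured in a functional assay on brain (Rattus norvegicus, strain Wistar) for inhibition (on this read-out lower numbers stand for stronger inhibition and higher numbers for weaker inhibition), so far
compound 1 `Cc1[nH]c(=O)n(C2CCCCC2)c1-c1ccc(CC(C)C)cc1` gives 10900 nM
compound 2 `CCCCCc1ccc(-c2c(C)[nH]c(=O)n2C2CCCCC2)cc1` gives 10600 nM
compound 3 `CCCCCCCOc1ccc(-c2c(C)[nH]c(=O)n2C2CCCCC2)cc1` gives 11600 nM

Compound 2 stands level with compound 1 and compound 3 in this assay with no gap beyond the scatter. Compound 4 `CCCCCCCCCCCCCCc1ccc(-c2c(C)[nH]c(=O)n2C2CCCCC2)cc1` differs from compound 2 by nonyl in place of hydrogen on a saturated chain carbon, five bonds along the chain from an aromatic carbon as nonyl in place of hydrogen on a saturated chain carbon, five bonds along the chain from an aromatic carbon. The measured chain swaps bear on this: a 1.0-fold lower number from compound 1 to compound 2 (0.01 log units; within the scatter) and a 1.1-fold higher number from compound 2 to compound 3 (0.04 log units; within the scatter) and also a 1.1-fold higher number from compound 1 to compound 3 (0.03 log units; within the scatter) as the third swap, all within the scatter. None reaches the chain length of compound 4, so this is an extrapolation. No step beyond the scatter is expected in this assay in either direction. The expected change is a 1.1-fold lower number from compound 2 to compound 4 (0.03 log units; within the scatter) on this estimate. Compound 4 is estimated at 10000 nM with a range from 3000 nM to 30000 nM as the likely span.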

Compound 4, half-maximal inhibitory concentration: > 100000 nM
Compound 4 was reported as a limit; the forecaster's own chance of this, stated with the estimate: 20%; middle value at least 10-fold (1.00 log units) from the limit.
By their numbers in this assay, from the lowest: compounds 2, 1 and 3 (each within the scatter of the next). At a limit, above all of these: compound 4.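

In this assay compound 4 is reported only as a limit, > 100000 nM. Nonyl in place of hydrogen on a saturated chain carbon, five bonds along the chain from an aromatic carbon, gives an at least 9.4-fold higher number from compound 2 to compound 4 (0.97 log units; beyond the scatter), the first step in these notes beyond the scatter, whereas compound 1, compound 2 and compound 3 stand level. From the compounds shown here alone, this position therefore does not accept every chain length, though the full size of the step remains unknown.

Still open, going by these compounds, is where between pentyl and the chain of compound 4 the loss sets in, for instance at octyl or decyl. Also open, on these data alone, is whether an amine or a carboxylic acid carried on this chain would change the reading.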